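Compound 3 to compound 4: one side chain exchanged

The source may report more compounds than this note shows. Statements on the series, on what has been measured and on what is new or still open speak of the compounds shown alone.

Compound 1 `N#Cc1ccc(NCCCn2ccnc2)cc1CN1CCN(C(c2ccccc2)c2ccccc2)CC1`: > 20000 nM (a limit of the assay)
Compound 2 `CN1CCCN(c2ccc(C#N)c(CN3CCN(C(c4ccccc4)c4ccc(Cl)cc4)CC3)c2)CC1`: 7340 nM
Compound 3 `N#Cc1ccc(NCCCn2ccnc2)cc1CN1CCN(C(c2ccccc2)c2ccc(Cl)cc2)CC1`: 5380 nM

All three compounds were tested in a toxicity assay on Huh-7.5 cells (Homo sapiens) for cytotoxicity, read by MTT assay, with a stated time of 96 h; a lower number here means that less compound is tolerated, a higher number that more compound is tolerated. Compound 1 reaches only a limit of the assay, > 20000 nM. Compound 3 stands at 5380 nM and compound 2 at 7340 nM, two values within the scatter of each other, so neither can be ranked over the other.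

Compound 4 `CN(C)CCN(C)CCN(C)c1ccc(C#N)c(CN2CCN(C(c3ccccc3)c3ccc(Cl)cc3)CC2)c1` keeps the rest of compound 3 and changes one group. On an aromatic carbon, para to a cyano group, (2-((2-(dimethylamino)ethyl)(methyl)amino)ethyl)(methyl)amino enters in place of (3-(1H-imidazol-1-yl)propyl)amino: (2-((2-(dimethylamino)ethyl)(methyl)amino)ethyl)(methyl)amino in place of (3-(1H-imidazol-1-yl)propyl)amino on an aromatic carbon.

The measured step that bears most directly on this change is a 1.4-fold lower number from compound 2 to compound 3 (0.13 log units; within the scatter), an exchange of groups at the same place that stays within the scatter. The other step, an at least 3.7-fold lower number from compound 1 to compound 3 (0.57 log units; beyond the scatter), is chloro in place of hydrogen, and compound 4 retains that chloro. A single exchange is a thin guide, but it gives no reason to expect a change beyond the scatter in this assay. The expected step is a 1.1-fold higher number from compound 3 to compound 4 (0.05 log units; within the scatter). For compound 4 the estimated half-maximal cytotoxic concentration is 6000 nM, with an expected range from 2500 nM to 14000 nM.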

Compound 4, half-maximal cytotoxic concentration: 6340 nM
Beside the measured number, compound 4's estimate is 1.1-fold (0.02 log units) below it; the range from low to high includes it.
By their numbers in this assay, from the lowest: compounds 3, 4 and 2 (each within the scatter of the next). At a limit, above all of these: compound 1.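

In this assay, the exchange of (3-(1H-imidazol-1-yl)propyl)amino, with its five-membered aromatic ring and one hydrogen-bond donor, for the ringless, donor-free (2-((2-(dimethylamino)ethyl)(methyl)amino)ethyl)(methyl)amino gives a 1.2-fold higher number from compound 3 to compound 4 (0.07 log units; within the scatter). Set against the ring-bearing 4-methyl-1,4-diazepan-1-yl at the same place, the same chain gives a 1.2-fold lower number from compound 2 to compound 4 (0.06 log units; within the scatter). The earlier compounds shown here offered a single exchange on this aromatic carbon, para to a cyano group, whereas compounds 2, 3 and 4 now show three different groups there that cannot be told apart in this assay, with or without a ring in the group and with or without a hydrogen-bond donor.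

The compounds shown leave open whether a group of another kind at this place, such as a carboxylic acid or a methoxy group, would separate from these three. The size of the chloro step also stays open, since compound 1, the only partner without the chloro, stands at a limit of the assay: the limit of > 20000 nM in this assay, at which 1 of the 4 values shown sits.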